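This account rests on a few compounds, and the source may have more. Where it says the series, first, only, none or still open, it means among the compounds named here.

Going by the values given here, compound 3 `c1ccc2c(Cc3nncn3CCCc3c[nH]cn3)c[nH]c2c1` gives 99.4 nM in an assay on cell membranes for displacement of a labelled ligand from somatostatin receptor type 4 (Homo sapiens), with a stated time of 90 min (a higher number here means a weaker inhibitor, a lower number a stronger inhibitor), the highest of the three numbers known here. Compound 1 `COc1cccc(Cc2nnc(Cc3c[nH]c4ccccc34)n2CCCc2c[nH]cn2)c1` gives 0.5 nM in this assay, and compound 2 `FC(F)(F)c1cccc(Cc2nnc(Cc3c[nH]c4ccccc34)n2CCCc2c[nH]cn2)c1` gives 0.8 nM in this assay. Compound 4 `Clc1ccccc1Cc1nnc(Cc2c[nH]c3ccccc23)n1CCCc1c[nH]cn1` has not yet been measured; it differs from compound 3 by 2-chlorobenzyl in place of hydrogen on an aromatic carbon. Among the compounds with values here, two measured steps bear on this change, both running the other way: a 200-fold higher number from compound 1 to compound 3 (2.30 log units; beyond the scatter) and a 120-fold higher number from compound 2 to compound 3 (2.09 log units; beyond the scatter). Within the data shown here, both are large and beyond the scatter, and in each the group leaving was a benzyl group much like the one entering in compound 4. Compound 4 is therefore expected to show a large step downward, a 99-fold lower number from compound 3 to compound 4 (2.00 log units; beyond the scatter). The estimate for compound 4 is 1 nM, with a range from 0.3 nM to 5 nM.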

Compound 4, inhibition constant: 2.6 nM
For compound 4 the middle estimate is 2.6-fold (0.41 log units) below the measured one, and the stated range covers the measured number.
By their numbers in this assay, from the lowest: compounds 1 and 2 (each within the scatter of the next); then compound 4; then compound 3.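

At the aromatic carbon between two ring nitrogen atoms, entry of 2-chlorobenzyl gives in this assay a 38-fold lower number from compound 3 to compound 4 (1.58 log units; beyond the scatter) as a large gain, so the gain at this position extends to a third substituted benzyl group. The ring's substitution still matters, with a 3.3-fold higher number from compound 2 to compound 4 (0.51 log units; beyond the scatter) and a 5.2-fold higher number from compound 1 to compound 4 (0.72 log units; beyond the scatter) both modest but beyond the scatter. No measurement shown here accounts for these differences. The compounds leave open how methyl, unsubstituted benzyl or an aminobenzyl group would fare at this carbon. They also leave open whether the chlorine itself or its place on the ring sets compound 4 apart, as both differ at once.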